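Swapping the aromatic substituent: from methyl to acetyl

A few compounds are considered here, and "the series" means these few. Any claim that something is new, unique, unknown or untested is made for them only; others in the source may bear on it.

Of the compounds shown here, three sharing one core have been measured in a functional assay on the whole organism for inhibition, with Rattus norvegicus as the target; a higher number here means that more compound is needed for the effect, a lower number that less compound is needed. Compound 1 `CC1CC/C(=N\Nc2ccc(Br)cc2)c2ncc(C(=O)O)c(=O)n21` gives 0.8 umol/kg, compound 2 `CC1CC/C(=N\Nc2ccc(O)cc2)c2ncc(C(=O)O)c(=O)n21` gives 1.7 umol/kg, and compound 3 `Cc1ccc(N/N=C2\CCC(C)n3c2ncc(C(=O)O)c3=O)cc1` gives 1.3 umol/kg. Compound 3 stands second highest of the three; its nearest neighbour is compound 2, its furthest is compound 1, and both gaps lie within the scatter. The measured steps all concern the same aromatic carbon: a 2.1-fold higher number from compound 1 to compound 2 (0.33 log units; beyond the scatter), a 1.6-fold higher number from compound 1 to compound 3 (0.21 log units; within the scatter), and a 1.3-fold lower number from compound 2 to compound 3 (0.12 log units; within the scatter). Only the first of these exceeds the scatter, so substituent swaps at this carbon have so far moved the number little.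

Compound 4 `CC(=O)c1ccc(N/N=C2\CCC(C)n3c2ncc(C(=O)O)c3=O)cc1` differs from compound 3 by acetyl in place of methyl on an aromatic carbon. For the measured compounds named here, no measured step involves an acetyl group, so the change must be judged from the narrow spread seen for bromo, hydroxy and methyl. Compound 4 is therefore expected to show a 1.2-fold higher number from compound 3 to compound 4 (0.09 log units; within the scatter), a step not clearly beyond the scatter. The estimate for compound 4 in this assay is 1.6 umol/kg, with a range from 0.6 umol/kg to 4.5 umol/kg.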

Compound 4, dose for 50% inhibition: 9.5 umol/kg
Beside the measured number, compound 4's estimate is 5.9-fold (0.77 log units) below it, outside the stated range (above it).
By their numbers in this assay, from the lowest: compounds 1, 3 and 2 (each within the scatter of the next, the first and the last beyond it); then compound 4.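

In this assay, for the compounds shown here, this aromatic carbon, para to a large group, turns out to tolerate less than the earlier compounds suggested: a 7.3-fold higher number from compound 3 to compound 4 (0.86 log units; beyond the scatter), and the picture holds against the other two substituents, with a 5.6-fold higher number from compound 2 to compound 4 (0.75 log units; beyond the scatter) and a 12-fold higher number from compound 1 to compound 4 (1.07 log units; beyond the scatter). Bromo, hydroxy and methyl had spanned only a narrow range, so acetyl, which brings a carbonyl and a hydrogen-bond acceptor, is the first group here to stand clearly apart from all three. No measurement at hand accounts for this rise.

The compounds shown leave open whether the rise goes with the carbonyl itself or simply with the added heavy atoms. An ethyl group, a methyl ester or an amide on the same carbon would help separate these two readings.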